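Swapping the Difluorophenyl Arm of Compound 1

A few compounds are considered here, and "the series" means these few. Any claim that something is new, unique, unknown or untested is made for them only; others in the source may bear on it.

Of the compounds shown here, three sharing one core have been tested in a functional assay on SGC-7901 cells (Homo sapiens) for antiproliferative activity, read by MTT assay, with a stated time of 72 h; on this read-out lower numbers stand for stronger inhibition and higher numbers for weaker inhibition. Compound 1 `COc1cc(-n2cnc3ccc(-c4cc(F)ccc4F)cc32)cc(OC)c1OC` gives 6590 nM, the highest of the three numbers, which means the weakest inhibition of cell growth. Compound 2 `COc1cc(-n2cnc3ccc(-c4cccc(Cl)c4)cc32)cc(OC)c1OC` gives 1490 nM, and compound 3 `COc1cc(-n2cnc3ccc(-c4cccc(C)c4C)cc32)cc(OC)c1OC` gives 3040 nM.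

Both measured steps away from compound 1 replace its 2,5-difluorophenyl group and both lower the number: a 4.4-fold lower number from compound 1 to compound 2 (0.65 log units; beyond the scatter), and a 2.2-fold lower number from compound 1 to compound 3 (0.34 log units; beyond the scatter). The step of a 2.0-fold higher number from compound 2 to compound 3 (0.31 log units; beyond the scatter) shows the two replacements differ from each other only modestly.

Compound 4 `COc1cc(-n2cnc3ccc(-c4ccc(O)cc4)cc32)cc(OC)c1OC` makes a third replacement at the same position: 4-hydroxyphenyl in place of 2,5-difluorophenyl on an aromatic carbon. Going by the values given here, because both a 4.4-fold lower number from compound 1 to compound 2 (0.65 log units; beyond the scatter) and a 2.2-fold lower number from compound 1 to compound 3 (0.34 log units; beyond the scatter) lowered the number modestly, a similar modest drop is expected here, with the exact size uncertain as no hydroxyl-bearing ring has yet been measured. The expected step is a 2.6-fold lower number from compound 1 to compound 4 (0.42 log units; beyond the scatter). Compound 4 is therefore estimated at 2500 nM, within a range from 900 nM to 7000 nM.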

Compound 4, half-maximal inhibitory concentration: > 10000 nM
Compound 4: no number, only a limit (the forecaster's own chance of this, stated with the estimate: 5%); at least 4.0-fold (0.60 log units) between middle value and limit.
By their numbers in this assay, from the lowest: compound 2; then compound 3; then compound 1. At a limit, above all of these: compound 4.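

In this assay compound 4 gives > 10000 nM, which is a limit of the assay and not a number. Going by these compounds alone, this position therefore does not reward every replacement of the 2,5-difluorophenyl group: the two earlier replacements lowered the number, but 4-hydroxyphenyl gives an at least 6.7-fold higher number from compound 2 to compound 4 (0.82 log units; beyond the scatter) and an at least 3.2-fold higher number from compound 3 to compound 4 (0.51 log units; beyond the scatter), so the choice of ring substituent matters here more than the earlier compounds suggested. The comparison with the starting compound is less firm, at an at least 1.5-fold higher number from compound 1 to compound 4 (0.18 log units; that floor lies within the scatter), so compound 4 cannot yet be placed clearly beyond compound 1.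

The compounds shown leave open whether the hydroxyl itself is what matters, or whether the loss of both fluorines plays a part. A methoxy group or an amine in place of the hydroxyl would help separate these possibilities.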